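A Chlorine Added to the Fused Ring of Compound 3

A few compounds are considered here, and "the series" means these few. Any claim that something is new, unique, unknown or untested is made for them only; others in the source may bear on it.

Three compounds built on one shared core have numbers in an assay on H9c2 cells for inhibition of tumor necrosis factor receptor superfamily member 6 (Rattus norvegicus), with stated times of 30 min and 6 h; a higher number here means that more compound is needed for the effect, a lower number that less compound is needed. Compound 1 `COC(=O)c1oc2ccccc2c1NC(=O)COc1ccc(Br)cc1` gives 1050 nM. Compound 2 `COC(=O)c1oc2cccc(Cl)c2c1NC(=O)CCSc1ccccn1` gives 631 nM. Compound 3 `COC(=O)c1oc2ccccc2c1NC(=O)CSc1ccc(Br)cc1` gives 661 nM, the second highest of the three numbers; its nearest neighbour is compound 2 and its furthest is compound 1, and both gaps lie within the scatter. Among the measured compounds shown here, the only step between measured compounds that differ in one place is a 1.6-fold lower number from compound 1 to compound 3 (0.20 log units; within the scatter), and it concerns the chain rather than the fused ring. Compound 4 `COC(=O)c1oc2cccc(Cl)c2c1NC(=O)CSc1ccc(Br)cc1` has not yet been measured; it differs from compound 3 by chloro in place of hydrogen on an aromatic carbon. For the measured compounds named here, no measured step tests this change on its own. Compound 2 carries the same chloro together with a different chain and gives 631 nM, which sits within the scatter of compound 3. The step from compound 3 to compound 4 is therefore expected to stay within the scatter, a 1.1-fold lower number from compound 3 to compound 4 (0.04 log units; within the scatter). Compound 4 is estimated at 600 nM, with a range from 250 nM to 1500 nM.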

Compound 4, half-maximal effective concentration: 1150 nM
Compound 4: middle estimate off by 1.9-fold (0.28 log units), on the low side, within the range that was stated.
By their numbers in this assay, from the lowest: compounds 2, 3, 1 and 4 (each within the scatter of the next).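

In this assay, chloro in place of hydrogen on an aromatic carbon, ortho to a fused ring and meta to a fused ring, now has a test of its own (a 1.7-fold higher number from compound 3 to compound 4 (0.24 log units; within the scatter)), and with the (4-bromophenyl)sulfanyl chain in place this change does not move the number beyond the scatter. Among the compounds shown here, with the chloro held constant, the chain can also be compared for the first time (a 1.8-fold higher number from compound 2 to compound 4 (0.26 log units; within the scatter)), and this change too stays within the scatter. Nothing available gives a reason for either result.

The compounds shown leave open whether fluoro, methoxy or an amine on that same aromatic carbon would give a step beyond the scatter. They also leave open whether a carboxylic acid in place of the methyl ester, or a longer chain, would do so.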